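The source may report more compounds than this note shows. Statements on the series, on what has been measured and on what is new or still open speak of the compounds shown alone.

Of the compounds shown here, three built on a shared core have been tested in a functional assay for activation of retinoic acid receptor alpha (Homo sapiens); a higher number here means a larger maximal response, a lower number a smaller maximal response. Compound 1 `CC1(C)CCC(C)(C)c2cc(C(O)c3ccc(/C=C/C(=O)O)cc3)ccc21` gives 0%, compound 2 `CC1(C)CCC(C)(C)c2cc(C(O)c3cccc(/C=C/C(=O)O)c3)ccc21` gives 0%, and compound 3 `C/C(=C\C(=O)O)c1ccc(C(=O)c2ccc3c(c2)C(C)(C)CCC3(C)C)cc1` gives 0%. Compound 3 thus stands level with compounds 1 and 2 at the digits reported, the agreement with each lying within the usual scatter. Compound 4 `CC1(C)CCC(C)(C)c2cc(C(=O)c3ccc(C#CC(=O)O)cc3)ccc21` has not yet been measured in this assay. It differs from compound 3 in one place: 2-carboxyethynyl in place of 2-carboxy-1-methylethenyl on an aromatic carbon. Going by the values given here, no step between two measured compounds is available to guide the expectation. Because compound 3 gives 0%, the step is expected to be no change at the digits printed from compound 3 to compound 4 (within the scatter), none beyond the scatter. Compound 4 is therefore expected to reach 0%, within a range from 0% to 10%.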

Compound 4, largest response reached (reported as maximum), in percent of the reference or control that the assay uses: 0%
Compound 4: the middle estimate sits on the measured number at the digits printed, within the range that was stated.
By their numbers in this assay, from the lowest: compounds 1, 2, 3 and 4 (each within the scatter of the next).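

Replacing 2-carboxy-1-methylethenyl with 2-carboxyethynyl on this aromatic carbon, para to a large group, gives no change at the digits printed from compound 3 to compound 4 (within the scatter) in this assay. Going by these compounds alone, this is the first step that can be read at this position, and it shows that a chain with a triple bond gives no more response here than the chain with its methyl-bearing double bond. No measurement available here bears on the reason for this result. With all four compounds level, the compounds shown do not reveal which groups at this position could produce a response. An amide in place of the carboxy group remains an open case.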